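The compounds below may be only part of what the source reports. "The series", "measured", "known", "first", "only" and "open" are said of these compounds alone.

Of the compounds shown here, three built on one shared core have been tested in a functional assay on MCF7 cells (Homo sapiens) for inhibition, read by MTT assay, with a stated time of 72 h, tested at 10 uM; a lower number here means less inhibition, a higher number more inhibition at the concentration tested (going by the name of the read-out). Compound 1, `CCOC(=O)C1=C(Nc2ccc(OC)cc2)S/C(=C\c2ccc[nH]2)C1=O`, carries a 4-methoxyphenyl on the amine nitrogen. In this assay compound 1 gives < 10%, which is a limit of the assay rather than a number. Compound 2, `CCOC(=O)C1=C(Nc2ccc(Br)cc2)S/C(=C\c2ccc[nH]2)C1=O`, carries a 4-bromophenyl there. In this assay compound 2 gives < 10%, again a limit. Compound 3, `CCOC(=O)C1=C(Nc2ccccc2Br)S/C(=C\c2ccc[nH]2)C1=O`, carries a 2-bromophenyl instead, and in this assay compound 3 gives 29.4%. That makes compound 3 the only one of the three with an actual number; the other two sit at a limit (the limit of < 10% in this assay, at which 2 of the 3 values shown sit).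

Two measured steps lead to compound 3. The step of a number at least 19.4 percentage points higher from compound 2 to compound 3 (beyond the scatter) and the step of a number at least 19.4 percentage points higher from compound 1 to compound 3 (beyond the scatter) both show that putting 2-bromophenyl in place of a 4-bromophenyl or a 4-methoxyphenyl raised inhibition beyond the scatter.

Compound 4, `CCOC(=O)C1=C(Nc2ccc(F)cc2)S/C(=C\c2ccc[nH]2)C1=O`, differs from compound 3 as follows: 4-fluorophenyl in place of 2-bromophenyl on an amine nitrogen. This returns to the kind of group that gave only limits in compound 1 and compound 2, so inhibition is expected to fall, by roughly a number 19.4 percentage points lower from compound 3 to compound 4 (beyond the scatter). Compound 4 is therefore estimated at 10%, within a range of 3% to 22%, and the assay may well report only a limit.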

Compound 4, a percentage reported as inhibition, at one concentration (the size of the read-out at that concentration, not a potency): < 10%
Compound 4 gave a limit, no number; the forecaster's own chance of this, stated with the estimate: 55%; the middle value sits exactly at the limit.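

The step of a number at least 19.4 percentage points lower from compound 3 to compound 4 (beyond the scatter) shows that the 2-bromophenyl group cannot be exchanged for 4-fluorophenyl on the amine nitrogen without losing the measurable inhibition. In this assay compound 4 gives < 10%, which is a limit of the assay and not a number. With 4-methoxyphenyl, 4-bromophenyl and now 4-fluorophenyl all ending at the same limit, compound 3 remains the only one of the four with an actual number: the limit of < 10% in this assay, at which 3 of the 4 values shown sit.

The steps among compound 1, compound 2 and compound 4 cannot be read, as all three values are limits, so nothing can be said about how these three groups rank against each other. Also open, as far as these compounds go, is whether the inhibition seen with compound 3 depends on bromine itself or would also appear with another group on the amine nitrogen, such as 2-fluorophenyl, 2-methylphenyl or 3-bromophenyl.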